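Dropping the chloro from the anilino arm

A few compounds are considered here, and "the series" means these few. Any claim that something is new, unique, unknown or untested is made for them only; others in the source may bear on it.

Compounds measured so far in a functional assay on A549 cells (Homo sapiens) for antiproliferative activity, read by MTT assay, with a stated time of 48 h; on this read-out higher numbers stand for weaker inhibition and lower numbers for stronger inhibition:
compound 1 `COC(=O)CN(C)c1nc(Nc2ccccc2)ncc1[N+](=O)[O-]`, giving > 100000 nM, a limit of the assay
compound 2 `COC(=O)CN(C)c1nc(Nc2ccc(Cl)cc2)ncc1[N+](=O)[O-]`, giving 23500 nM
compound 3 `CCOC(=O)CN(Cc1ccccc1)c1nc(Nc2ccc(Cl)cc2)ncc1[N+](=O)[O-]`, giving > 100000 nM, a limit of the assay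

Compound 3 stands at the edge of what this assay reports: its value is a limit, not a number, and it shares that position with compound 1 at the limit of > 100000 nM in this assay, at which 2 of the 3 values shown sit. Compound 4 `CCOC(=O)CN(Cc1ccccc1)c1nc(Nc2ccccc2)ncc1[N+](=O)[O-]` differs from compound 3 by hydrogen in place of chloro on an aromatic carbon.

Within the data shown here, only one measured step bears on this change, and it runs in the opposite direction: an at least 4.2-fold lower number from compound 1 to compound 2 (0.62 log units; beyond the scatter). That step, chloro in place of hydrogen on an aromatic carbon, is the mirror image of the change from compound 3 to compound 4, where hydrogen replaces chloro. Undoing it would be expected to give either a higher number or no step beyond the scatter. Since compound 3 is already at the limit, compound 4 is expected to sit at or past that limit as well.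

Compound 4 is therefore estimated at 200000 nM, with a range from 60000 nM to 1000000 nM. The step this estimate implies is a step that the limit leaves unreadable from compound 3 to compound 4, and the result is expected most likely to be reported only as a limit.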

Compound 4, half-maximal inhibitory concentration: > 100000 nM
Compound 4 was reported as a limit; the forecaster's own chance of this, stated with the estimate: 85%; the middle value is on the limit's open side.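

Compound 4 gives > 100000 nM, a limit of the assay. Compound 3 is also reported only as a limit, so no step can be read between compound 3 and compound 4: the limit of > 100000 nM in this assay, at which 3 of the 4 values shown sit.

The compounds shown leave open how far past the limit compound 3 and compound 4 lie, and whether the chloro matters in this pair.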